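From 1H-indol-6-yl to (1H-indol-5-yl)methyl on a shared core

The source may hold more compounds than are shown below. What is called first, only, known or untested is meant among the compounds shown, and "the series" means these compounds.

Of the compounds shown here, three with a shared core have been measured in a functional assay on DU-145 cells (Homo sapiens) for inhibition, read by trypan blue exclusion, with a stated time of 72 h; a higher number here means a weaker inhibitor, a lower number a stronger inhibitor. Compound 1 `Cn1c(=O)c(S(=O)(=O)c2ccc(F)cc2F)cc2cnc(Nc3cnc4[nH]ccc4c3)nc21` gives 750 nM, compound 2 `Cn1c(=O)c(S(=O)(=O)c2ccc(F)cc2F)cc2cnc(Nc3ccc4cccc(O)c4n3)nc21` gives 5000 nM, and compound 3 `Cn1c(=O)c(S(=O)(=O)c2ccc(F)cc2F)cc2cnc(Nc3ccc4cc[nH]c4c3)nc21` gives 5000 nM. The highest number of the three is therefore held jointly, with no change at the digits printed from compound 2 to compound 3 (within the scatter). Both of the other steps are larger: a 6.7-fold higher number from compound 1 to compound 2 (0.82 log units; beyond the scatter) and a 6.7-fold higher number from compound 1 to compound 3 (0.82 log units; beyond the scatter).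

Compound 4 `Cn1c(=O)c(S(=O)(=O)c2ccc(F)cc2F)cc2cnc(NCc3ccc4[nH]ccc4c3)nc21` carries (1H-indol-5-yl)methyl in place of 1H-indol-6-yl, on a nitrogen on an aromatic ring: (1H-indol-5-yl)methyl in place of 1H-indol-6-yl on a nitrogen on an aromatic ring. For the measured compounds named here, no measured compound carries this group, so no step measures the change directly. The three measured steps all change the group at this same place, and they offer only indirect guidance. Their largest size is a 6.7-fold higher number from compound 1 to compound 3 (0.82 log units; beyond the scatter), and that step leads to compound 3 rather than away from it. The data give no reason to favour a direction, so the expected result is no change at the digits printed from compound 3 to compound 4 (within the scatter). For compound 4 the estimate is 5000 nM, with an expected range from 1800 nM to 14000 nM.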

Compound 4, half-maximal inhibitory concentration: 100000 nM
Compound 4: the middle estimate sits 20-fold (1.30 log units) below what was measured; the whole stated range lies below it.
By their numbers in this assay, from the lowest: compound 1; then compounds 2 and 3 (each within the scatter of the next); then compound 4.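

In this assay, for the compounds shown here, replacing 1H-indol-6-yl with (1H-indol-5-yl)methyl on this nitrogen gives a 20-fold higher number from compound 3 to compound 4 (1.30 log units; beyond the scatter), a larger step than any among the earlier compounds. The distance to the other two compounds is as wide or wider, with a 20-fold higher number from compound 2 to compound 4 (1.30 log units; beyond the scatter) and a 130-fold higher number from compound 1 to compound 4 (2.12 log units; beyond the scatter), so this position can move the number much further than compounds 1 to 3 had shown, and the one group of the four that enters through a methyl gives the highest number. Nothing at hand accounts for the size of this rise.

The change adds the methyl and also moves the indole attachment from 6-yl to 5-yl, and the compounds shown do not separate the two; 1H-indol-5-yl on the same nitrogen would do so. On these data alone, how a longer chain, such as 2-(1H-indol-5-yl)ethyl, would read also remains open.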